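A few compounds are considered here, and "the series" means these few. Any claim that something is new, unique, unknown or untested is made for them only; others in the source may bear on it.

Compound 1 `C[C@H]1CC[C@@H]2[C@@H](OC(=O)[C@]23CC(c2ccccc2Br)=NO3)[C@]2(C)C(=O)C=C[C@@]12O`: 51000 nM
Compound 2 `C[C@H]1CC[C@@H]2[C@@H](OC(=O)[C@]23CC(c2ccccc2[N+](=O)[O-])=NO3)[C@]2(C)C(=O)C=C[C@@]12O`: 37000 nM

In a functional assay on PC-3 cells (Homo sapiens) for cytotoxicity, read by sulforhodamine B assay, with a stated time of 48 h (on this read-out higher numbers stand for weaker inhibition and lower numbers for stronger inhibition), compound 2 gives 37000 nM, which lies within the scatter of compound 1 at 51000 nM. Both compounds thus sit at the same level in the high micromolar range. Compound 3 `C[C@H]1CC[C@@H]2[C@@H](OC(=O)[C@]23CC(c2cccc([N+](=O)[O-])c2)=NO3)[C@]2(C)C(=O)C=C[C@@]12O` is the next compound to be considered. It keeps the core of compound 2 and differs in one group: 3-nitrophenyl in place of 2-nitrophenyl on a carbon with a double bond to nitrogen. Going by the values given here, the only measured step is a 1.4-fold lower number from compound 1 to compound 2 (0.14 log units; within the scatter), with nitro in place of bromo on an aromatic carbon, and it stays within the scatter. Among the compounds with values here, no measured pair tests a move of the nitro group, so this evidence is indirect. No change beyond the scatter is expected in this assay, and no direction is favoured. The expected step is a 1.0-fold higher number from compound 2 to compound 3 (0.01 log units; within the scatter). Compound 3 is estimated at 38000 nM, with an expected range of 18000 nM to 80000 nM.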

Compound 3, half-maximal inhibitory concentration: 55000 nM
Compound 3: middle estimate off by 1.4-fold (0.16 log units), on the low side; measured number inside the range.
By their numbers in this assay, from the lowest: compounds 2, 1 and 3 (each within the scatter of the next).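

Moving the nitro group on the phenyl ring attached to the carbon with a double bond to nitrogen gives a 1.5-fold higher number from compound 2 to compound 3 (0.17 log units; within the scatter) in this assay and so stays level. Exchanging 2-bromophenyl for 3-nitrophenyl at the same carbon gives a 1.1-fold higher number from compound 1 to compound 3 (0.03 log units; within the scatter) and is level as well, so among these three compounds neither the nitro group's move nor the change of group separates the numbers. Nothing available explains why these values stay together.

Going by these compounds, it remains open whether 4-nitrophenyl would also stay level with these three compounds. On these data alone, it is equally open whether an amine or a carboxylic acid on the phenyl ring, or a longer alkyl chain in place of the ring, would move the number beyond the scatter.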